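Swapping a Methoxy for a Methylsulfonyl on the Pyrazole Chain

The source may report more compounds than this note shows. Statements on the series, on what has been measured and on what is new or still open speak of the compounds shown alone.

Of the compounds shown here, two sharing one core have been tested in an assay on isolated protein for inhibition of protein deacetylase HDAC6 (Homo sapiens), read by fluorescence; on this read-out higher numbers stand for weaker inhibition and lower numbers for stronger inhibition. Compound 1 `C=CCCn1cc(-c2nc(Nc3ccc(NC(=O)CCCCCCC(=O)NO)cc3)nc3[nH]ccc23)cn1` gives 0.25 nM in this assay, and compound 2 `COCCn1cc(-c2nc(Nc3ccc(NC(=O)CCCCCCC(=O)NO)cc3)nc3[nH]ccc23)cn1` gives 2.1 nM. Among the measured compounds shown here, compound 2 therefore stands at the higher of the two numbers, meaning the weaker inhibition; its only neighbour is compound 1, and the single known step is an 8.4-fold higher number from compound 1 to compound 2 (0.92 log units; beyond the scatter), a change of a vinyl for a methoxy on a saturated chain carbon, two bonds along the chain from an aromatic nitrogen.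

Compound 3 `CS(=O)(=O)CCn1cc(-c2nc(Nc3ccc(NC(=O)CCCCCCC(=O)NO)cc3)nc3[nH]ccc23)cn1` has not been measured. It differs from compound 2 by methylsulfonyl in place of methoxy on a saturated chain carbon, two bonds along the chain from an aromatic nitrogen. For the measured compounds named here, no measured step replaces a methoxy with a methylsulfonyl, so the step from compound 1 to compound 2 bears on it only loosely: it shows that exchanging the group at this chain position can move this assay by a modest amount, and it gives no guide to direction here. A change beyond the scatter is therefore not expected with confidence, though a slight move toward a higher number seems somewhat more likely than a lower one. The step from compound 2 to compound 3 is estimated at a 1.5-fold higher number from compound 2 to compound 3 (0.18 log units; within the scatter). Compound 3 is expected to give about 3.2 nM in this assay, with a range from 0.8 nM to 12 nM.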

Compound 3, half-maximal inhibitory concentration: 2.3 nM
Beside the measured number, compound 3's estimate is 1.4-fold (0.14 log units) above it; low and high end bracket the measured number.
By their numbers in this assay, from the lowest: compound 1; then compounds 2 and 3 (each within the scatter of the next).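

In this assay, the step from methoxy to methylsulfonyl on a saturated chain carbon, two bonds along the chain from an aromatic nitrogen, is a 1.1-fold higher number from compound 2 to compound 3 (0.04 log units; within the scatter). This step brings in 4 heavy atoms in place of 2, and 2 hydrogen-bond acceptors in place of 1, yet the two numbers cannot be told apart, so at this position the read-out does not follow these counts across this one pair. Compound 1 now stands apart from two compounds rather than one, with a 9.2-fold higher number from compound 1 to compound 3 (0.96 log units; beyond the scatter) alongside an 8.4-fold higher number from compound 1 to compound 2 (0.92 log units; beyond the scatter), so among these three the vinyl-ended chain alone gives the lowest number, and no compound shown goes against this; no measurement here offers a reason for either result.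

Going by these compounds, what remains open is whether that lower number belongs to the vinyl group itself or would also appear with a plain butyl chain, which would have no double bond at its end. On these data alone, it is also open whether an amine or a carboxylic acid at this place would stay level with compound 2 and compound 3 or move away from them.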